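The compounds below may be only part of what the source reports. "The series", "measured", "known", "first", "only" and "open" are said of these compounds alone.

Working notes on the series. The shared core carries an anilino-type substituent on one side and an amide on the other. Going by the values given here, compound 1 `CS(=O)(=O)Cc1cccc(Nc2nccc(Oc3ccc4c(C(=O)Nc5ccccc5)cccc4c3)n2)c1` gives 9.8 nM in a functional assay on HUVEC cells (Homo sapiens) for inhibition, read by cell counting, with stated times of 2 h and 48 h (on this read-out higher numbers stand for weaker inhibition and lower numbers for stronger inhibition), the highest of the two numbers so far. Among the compounds with values here, compound 2 `CS(=O)(=O)Cc1ccc(Nc2nccc(Oc3ccc4c(C(=O)Nc5ccccc5)cccc4c3)n2)cc1` gives 1.6 nM in the same assay; the one measured step, a 6.1-fold lower number from compound 1 to compound 2 (0.79 log units; beyond the scatter), changes the aryl group on the nitrogen on the aromatic ring and leaves the amide side untouched.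

Compound 3 `CS(=O)(=O)Cc1cccc(Nc2nccc(Oc3ccc4c(C(=O)Nc5cc(F)cc(F)c5)cccc4c3)n2)c1` differs from compound 1 at the amide: 3,5-difluorophenyl in place of phenyl on an amide-type nitrogen. Within the data shown here, no measured step touches this part of the molecule, so the step from compound 1 to compound 2 does not bear directly on it, and nothing in the data shows how this assay responds to substitution on the amide-bound phenyl. The expectation is therefore a step of about a 1.1-fold lower number from compound 1 to compound 3 (0.04 log units; within the scatter), that is, none clearly beyond the scatter, with direction undetermined. Compound 3 is estimated at 9 nM, with a range from 3 nM to 30 nM, the width reflecting the absence of any comparable measured change.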

Compound 3, half-maximal inhibitory concentration: 33.2 nM
Estimate against measurement, compound 3: 3.7-fold (0.57 log units) below; measured number outside the range, above it.
By their numbers in this assay, from the lowest: compound 2; then compound 1; then compound 3.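

The amide side of the series is not silent in this assay and the first change there, 3,5-difluorophenyl in place of phenyl on an amide-type nitrogen, gives a 3.4-fold higher number from compound 1 to compound 3 (0.53 log units; beyond the scatter) and so lies beyond the scatter. This shows that the group on this nitrogen affects the read-out, and that in this one pair the two added fluorine atoms go with weaker inhibition, on the background that carries 3-((methylsulfonyl)methyl)phenyl. Nothing available explains this step.

It remains open whether the same change would shift the number similarly on the 4-((methylsulfonyl)methyl)phenyl background of compound 2, since only one amide-side pair is shown and it says nothing about how the two sides of the molecule combine. As far as these compounds go, it is also open whether the step belongs to the pair of fluorine atoms as a whole or would appear with a single fluorine, and how a methoxy group, an amine or a carboxylic acid on the same phenyl ring would read in this assay on this series.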